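Swapping the methoxy-bearing ring for a chloromethyl one

The source may report more compounds than this note shows. Statements on the series, on what has been measured and on what is new or still open speak of the compounds shown alone.

Of the compounds shown here, three sharing one core have been measured in a functional assay on KB cells (Homo sapiens) for antiproliferative activity, read by sulforhodamine B assay, with a stated time of 3 days; a lower number here means that less compound is needed, a higher number that more compound is needed for the effect. Compound 1 `CCC1=C(O)c2c(oc(-c3ccc(C)cc3)cc2=O)C(CC)(CC)C1=O` gives 39.2 uM, and compound 2 `CCC1=C(O)c2c(oc(-c3ccc(OC)cc3)cc2=O)C(CC)(CC)C1=O` gives 17.7 uM, the lowest of the two plain numbers. Compound 3 `CCC1=C(O)c2c(oc(-c3cccc(OC(F)(F)F)c3)cc2=O)C(CC)(CC)C1=O` reaches only a limit of the assay, > 47.4 uM, as noted in the limit of > 47.4 uM in this assay, at which 1 of the 3 values shown sits. Within the data shown here, the single comparable step, a 2.2-fold lower number from compound 1 to compound 2 (0.35 log units; beyond the scatter), is modest. Compound 4 `CCC1=C(O)c2c(oc(-c3ccc(C)c(Cl)c3)cc2=O)C(CC)(CC)C1=O` carries 3-chloro-4-methylphenyl in place of 4-methoxyphenyl on an aromatic carbon, that is, 3-chloro-4-methylphenyl in place of 4-methoxyphenyl on an aromatic carbon; the methoxy that set compound 2 apart from compound 1 is gone, and a methyl returns alongside a chlorine. Among the measured compounds shown here, the one step that bears on this is a 2.2-fold lower number from compound 1 to compound 2 (0.35 log units; beyond the scatter), so a modest rise is expected, roughly reversing it as a 1.8-fold higher number from compound 2 to compound 4 (0.26 log units; within the scatter). Compound 4 is therefore estimated at 32 uM, within 12 uM to 70 uM.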

Compound 4, concentration for half-maximal effect: 39 uM
For compound 4 the middle estimate is 1.2-fold (0.09 log units) below the measured one; the measured number falls inside the stated range.
By their numbers in this assay, from the lowest: compound 2; then compounds 4 and 1 (each within the scatter of the next). At a limit, above all of these: compound 3.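

The change to 3-chloro-4-methylphenyl brings a 2.2-fold higher number from compound 2 to compound 4 (0.34 log units; beyond the scatter) and so gives up the advantage compound 2 held with its 4-methoxyphenyl. Chloro in place of hydrogen on the ring of compound 1 leaves no readable effect, with a 1.0-fold lower number from compound 1 to compound 4 (0.00 log units; within the scatter) and so no difference between the two. Among these three plain numbers, then, only the compound with methoxy stands apart, and adding chlorine to a methyl-bearing ring does not recover its value.

Nothing measured here explains either step. As far as these compounds go, whether an amine or a hydroxyl group on that ring would match compound 2 remains open.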